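This account rests on a few compounds, and the source may have more. Where it says the series, first, only, none or still open, it means among the compounds named here.

- compound 1 `O=C(Nc1cccc(Cl)c1)Nc1ccc(-c2cc(=O)c3ccccc3o2)c(Cl)c1` gives 14000 nM
- compound 2 `COc1ccc2oc(-c3ccc(NC(=O)Nc4ccc(Cl)c(Cl)c4)cc3Cl)cc(=O)c2c1` gives 15600 nM

Within the data shown here, in a functional assay on A549 cells (Homo sapiens) for inhibition, read by MTT assay, with a stated time of 48 h (a higher number here means a weaker inhibitor, a lower number a stronger inhibitor), compound 1 and compound 2 lie within the scatter of each other, so compound 1 stands level with the only other number. Compound 3 `O=C(Nc1cccc(Cl)c1)Nc1ccc(-c2cc(=O)c3cc(F)ccc3o2)c(Cl)c1` is compound 1 with one change: fluoro in place of hydrogen on an aromatic carbon of a six-membered aromatic ring of carbon only, part of a fused or bridged system of two rings. Among the measured compounds shown here, no two measured compounds differ in one place only, so the series offers no direct guide to this change. With compound 1 at 14000 nM as the starting point, no step beyond the scatter is expected in this assay and no direction is favoured. The expected step is a 1.1-fold lower number from compound 1 to compound 3 (0.03 log units; within the scatter) and it stays within the scatter. For compound 3 the expected value is 13000 nM with an estimated range from 5500 nM to 30000 nM in this series.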

Compound 3, half-maximal inhibitory concentration: > 50000 nM
Compound 3 was reported as a limit; the forecaster's own chance of this, stated with the estimate: 5%; middle value at least 3.8-fold (0.58 log units) away from the limit.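

In this assay, fluoro in place of hydrogen on an aromatic carbon of the six-membered aromatic ring of carbon only, part of a fused or bridged system of two rings, is not a silent change: the series records an at least 3.5-fold higher number from compound 1 to compound 3 (0.55 log units; beyond the scatter). Among these compounds, compound 3 stands at a limit, > 50000 nM, not a number, so the step has a lower bound and no measured end: the limit of > 50000 nM in this assay, at which 1 of the 3 values shown sits. Compound 1 and compound 2 differ in more than one place, so this is the first reading of a single change on the shared core.

On these data alone, whether the step belongs to fluoro itself or would follow with a hydroxyl, an amine or a methyl group on the same carbon stays open. Also open, as far as these compounds go, is whether fluoro on the other aromatic carbons of that ring gives a similar step.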